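The source may report more compounds than this note shows. Statements on the series, on what has been measured and on what is new or still open speak of the compounds shown alone.

Measured so far:
Compound 1, `CCCOC(=O)c1cc(N2C(=O)C3=C(CCCC3)C2=O)c(F)cc1Cl`; in a functional assay on the whole organism with Scenedesmus acutus as the target (on this read-out higher numbers stand for weaker inhibition and lower numbers for stronger inhibition), compound 1 gives 89.1 nM.
Compound 2, `CCCOC(=O)c1cc(N2C(=O)C3=C(CCCC3)C2=O)ccc1Cl`; in this assay compound 2 gives 1860 nM.

For the measured compounds named here, compound 2 stands highest of the two numbers, and its only neighbour is compound 1: the step of a 21-fold higher number from compound 1 to compound 2 (1.32 log units; beyond the scatter) is large and beyond the scatter, reached by putting hydrogen in place of fluoro on an aromatic carbon.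

Compound 3, `CCCCCOC(=O)c1cc(N2C(=O)C3=C(CCCC3)C2=O)ccc1Cl`, has not been measured. It differs from compound 2 by ethyl in place of hydrogen on a saturated chain carbon, three bonds along the chain from an oxygen next to a carbonyl group; cut one bond further out, the same difference reads propyl to pentyl. Going by the values given here, the single measured step, a 21-fold higher number from compound 1 to compound 2 (1.32 log units; beyond the scatter), concerns a fluoro on the aromatic ring and says nothing about the ester chain, so no measured step bears on this change. The expected step is therefore no change at the digits printed from compound 2 to compound 3 (within the scatter), nothing beyond the scatter. Compound 3 is estimated at 1860 nM, with a range from 500 nM to 7000 nM in this assay.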

Compound 3, half-maximal inhibitory concentration: 9330 nM
Estimate against measurement, compound 3: 5.0-fold (0.70 log units) below; the whole stated range lies below it.
By their numbers in this assay, from the lowest: compound 1; then compound 2; then compound 3.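

The chain on the oxygen next to the carbonyl group is not a silent part of these molecules: going from propyl to pentyl, a 5.0-fold higher number from compound 2 to compound 3 (0.70 log units; beyond the scatter) in this assay, a move towards weaker inhibition. For the compounds shown here, this is the first measured sign that the chain matters as well as the fluoro on the aromatic ring, and here the added ethyl costs activity, though only modestly. Nothing available explains why the longer chain gives the higher number.

Going by these compounds alone, with only two chain lengths in hand, the shape of the trend stays open: a butyl chain could fall between them, and a methyl or ethyl chain, or a carboxylic acid in place of the ester, could go either way. On these data alone, it is also open whether lengthening the chain would have the same effect with the fluoro of compound 1 in place.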